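From Isopropyl to Isobutyl in a Cytotoxicity Series

This account rests on a few compounds, and the source may have more. Where it says the series, first, only, none or still open, it means among the compounds named here.

In an ADME assay on MDCK cells (Canis lupus familiaris) for cytotoxicity, read by MTT assay, with a stated time of 48 h (a higher number here means that more compound is tolerated, a lower number that less compound is tolerated), compound 1 (`Cc1cccc(NC(=O)CSc2nc(-c3ccccc3)cc(-c3ccccc3)c2C#N)c1`) reports > 250000 nM as a limit of the assay, not a number. Within the data shown here, compound 2 (`COC(=O)[C@@H](NC(=O)CSc1nc(-c2ccccc2)cc(-c2ccc(C)cc2)c1C#N)C(C)C`) gives 210000 nM in this assay and so holds the only actual number so far. Compound 3 (`COC(=O)[C@H](CC(C)C)NC(=O)CSc1nc(-c2ccccc2)cc(-c2ccc(C)cc2)c1C#N`) has yet to be measured there. It differs from compound 2 in one place, isobutyl in place of isopropyl on a saturated chain carbon bound to an amide-type nitrogen and a carbonyl carbon on a saturated chain carbon bound to an amide-type nitrogen and a carbonyl carbon. Among the measured compounds shown here, no measured pair shows what this exchange does, so the expectation rests on compound 2 at 210000 nM alone. No change beyond the usual scatter is expected in this assay, and neither direction is favoured. The expected step of a 1.1-fold lower number from compound 2 to compound 3 (0.04 log units; within the scatter) is correspondingly small. Compound 3 is estimated at 190000 nM in this assay, with an expected range from 100000 nM to 300000 nM around that estimate.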

Compound 3, half-maximal cytotoxic concentration: 215000 nM
Compound 3: the middle estimate sits 1.1-fold (0.05 log units) below what was measured; measured number inside the range.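

Among these compounds, compound 2 and compound 3 give the first pair that reads this position directly: in this assay, isobutyl in place of isopropyl on a saturated chain carbon bound to an amide-type nitrogen and a carbonyl carbon gives a 1.0-fold higher number from compound 2 to compound 3 (0.01 log units; within the scatter) for this exchange. Going from 3 carbon atoms to 4 in this branched alkyl group therefore leaves the tolerated concentration indistinguishable between the two compounds, which compound 2 alone could not show. Compound 1 reports a limit and not a number, so it gives no second reading of this kind: the limit of > 250000 nM in this assay, at which 1 of the 3 values shown sits.

Among the compounds shown here, this single pair covers only two branched alkyl groups. On these data alone, whether a longer chain, a benzyl group or an amine at this position, or a carboxylic acid in place of the methoxycarbonyl group, would move the number beyond the scatter remains open.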